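The source may report more compounds than this note shows. Statements on the series, on what has been measured and on what is new or still open speak of the compounds shown alone.

In an ADME assay on MT4 cells (Homo sapiens) for cytotoxicity, read by MTT assay, with a stated time of 5 days (a higher number here means that more compound is tolerated, a lower number that less compound is tolerated), compound 3 (`COc1cc2nc([S+]([O-])CC(=O)Nc3ccc(C#N)cc3)nc(Nc3c(Cl)cc(/C=C/C#N)cc3Cl)c2cc1OC`) gives >= 188000 nM, which is a limit and not a number. Compound 1 (`COc1cc2nc([S+]([O-])CC(=O)Nc3ccccc3[N+](=O)[O-])nc(Nc3c(Cl)cc(/C=C/C#N)cc3Cl)c2cc1OC`) gives > 199000 nM, also a limit. Among the measured compounds shown here, compound 2 (`COc1cc2nc([S+]([O-])CC(=O)Nc3cccc(C(F)(F)F)c3)nc(Nc3c(Cl)cc(/C=C/C#N)cc3Cl)c2cc1OC`) is the only one with a true number, at 21800 nM in this series.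

Compound 4 (`COc1ccccc1NC(=O)C[S+]([O-])c1nc(Nc2c(Cl)cc(/C=C/C#N)cc2Cl)c2cc(OC)c(OC)cc2n1`) differs from compound 3 by a single change, (2-methoxyphenyl in place of 4-cyanophenyl on an amide-type nitrogen), which puts 2-methoxyphenyl in place of 4-cyanophenyl on an amide-type nitrogen. The measured swaps at this same nitrogen bear on it. They gave an at least 9.1-fold lower number from compound 1 to compound 2 (0.96 log units; beyond the scatter) and an at least 8.6-fold higher number from compound 2 to compound 3 (0.93 log units; beyond the scatter), both beyond the scatter, while a step that the two limits leave unreadable from compound 1 to compound 3 cannot be sized.

Two of the three values are limits. Compound 2 at 21800 nM shows that a swap here can lower the number considerably. A modest move toward a lower number is therefore expected in this assay. The expected step is an at least 2.0-fold lower number from compound 3 to compound 4 (0.31 log units; beyond the scatter) in size. For compound 4 the estimate is 90000 nM, with an expected range from 25000 nM to 200000 nM.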

Compound 4, half-maximal cytotoxic concentration: > 204000 nM
Compound 4: a limit, no number; the forecaster's own chance of this, stated with the estimate: 40%; middle value at least 2.2-fold (0.35 log units) from the limit.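

In this assay, the 2-methoxyphenyl group on the amide-type nitrogen leaves compound 4 at a limit and not a number, as the 2-nitrophenyl group of compound 1 and the 4-cyanophenyl group of compound 3 did. The one readable step, an at least 9.3-fold higher number from compound 2 to compound 4 (0.97 log units; beyond the scatter), sets compound 2 apart once more: among these four compounds, only its 3-(trifluoromethyl)phenyl group gives a true number at this nitrogen. The steps to compound 4 from compound 1 and from compound 3 cannot be read, because each joins two limits: the limit of > 204000 nM in this assay, at which 1 of the 4 values shown sits.

As far as these compounds go, how compound 1, compound 3 and compound 4 rank among themselves stays open. From the compounds shown here alone, it is also open whether a phenyl group carrying an amine or a carboxylic acid on this nitrogen would give a true number, as compound 2 does.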